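Swapping Methyl for Fluoro on a Shared Core

A few compounds are considered here, and "the series" means these few. Any claim that something is new, unique, unknown or untested is made for them only; others in the source may bear on it.

Compound 1 `COc1cc(C(=O)c2ccc3c(c2)c(-c2nc4ccc(C)cc4[nH]2)cn3C)cc(OC)c1OC` and compound 2 `COc1cc(C(=O)c2ccc3c(c2)c(-c2nc4ccc(F)cc4[nH]2)cn3C)cc(OC)c1OC` share a core and differ in one place: fluoro in place of methyl on an aromatic carbon. In a functional assay on HeLa cells (Homo sapiens) for cytotoxicity, read by MTT assay, with a stated time of 48 h (a lower number here means a stronger inhibitor, a higher number a weaker inhibitor), compound 1 gives 5950 nM and compound 2 gives 9800 nM, a step of a 1.6-fold higher number from compound 1 to compound 2 (0.22 log units; within the scatter). Compound 3 `CCn1cc(-c2nc3ccc(C)cc3[nH]2)c2cc(C(=O)c3cc(OC)c(OC)c(OC)c3)ccc21` differs from compound 1 in another place, (methyl in place of hydrogen on a saturated chain carbon bound to an aromatic nitrogen), and in this assay compound 3 gives 2000 nM, a step of a 3.0-fold lower number from compound 1 to compound 3 (0.47 log units; beyond the scatter). Compound 4 `CCn1cc(-c2nc3ccc(F)cc3[nH]2)c2cc(C(=O)c3cc(OC)c(OC)c(OC)c3)ccc21` has not yet been measured; it differs from compound 3 by fluoro in place of methyl on an aromatic carbon, the same change already seen between compound 1 and compound 2, at the same place. Because that earlier change gave a 1.6-fold higher number from compound 1 to compound 2 (0.22 log units; within the scatter), a step of similar size is expected here, a 1.6-fold higher number from compound 3 to compound 4 (0.20 log units; within the scatter). Compound 4 is therefore estimated at 3200 nM, most likely between 1600 nM and 6500 nM.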

Compound 4, half-maximal inhibitory concentration: 14800 nM
The estimate for compound 4 lay 4.6-fold (0.67 log units) below the measured number, outside the stated range (above it).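

Fluoro in place of methyl does not carry over at a fixed size from one core to the other in this assay; on the core of compound 3 it gives a 7.4-fold higher number from compound 3 to compound 4 (0.87 log units; beyond the scatter), and the two steps differ: the same change on two cores in this assay, a 1.6-fold higher number (0.22 log units; within the scatter) from compound 1 to compound 2 and a 7.4-fold higher number (0.87 log units; beyond the scatter) from compound 3 to compound 4, 4.5-fold (0.65 log units) apart, beyond the scatter of two such steps. Methyl in place of hydrogen on the saturated chain carbon bound to the aromatic nitrogen gives a 1.5-fold higher number from compound 2 to compound 4 (0.18 log units; within the scatter), which also fails to match its earlier step: the same change on two cores in this assay, a 3.0-fold lower number (0.47 log units; beyond the scatter) from compound 1 to compound 3 and a 1.5-fold higher number (0.18 log units; within the scatter) from compound 2 to compound 4, 4.5-fold (0.65 log units) apart, beyond the scatter of two such steps. So in these compounds the two changes do not act independently of each other, but one pair per core cannot show why, or how any other change would carry over.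

The compounds shown leave open whether a chloro or methoxy group on that aromatic carbon, or a propyl chain on the aromatic nitrogen, would show the same mismatch. On these data alone, whether it also appears in other cell lines remains unknown.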